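The source may hold more compounds than are shown below. What is called first, only, known or untested is meant among the compounds shown, and "the series" means these compounds.

Measured so far in a functional assay on CHO-K1 cells for antagonist activity at adenosine receptor A1 (Homo sapiens), read by a beta-galactosidase reporter and cAMP accumulation, with stated times of 15 min and 6 h; a lower number here means a stronger inhibitor, a higher number a weaker inhibitor:
compound 1 `CC(C)c1ccc(-c2nc(N)c3cc(Cc4ccccc4)sc3n2)o1`: 283 nM
compound 2 `COc1ccccc1Cc1cc2c(N)nc(-c3cccc(C#N)c3)nc2s1`: 129 nM
compound 3 `N#Cc1cccc(-c2nc(N)c3cc(C4(c5ccccc5)CC4)sc3n2)c1`: a limit only, > 610 nM

Of the two numbers actually read, compound 1 gives the higher one, that is the weaker inhibition, with compound 2 the nearest at a lower value; the gap between them is beyond the usual scatter. For compound 3 the limit of > 610 nM in this assay, at which 1 of the 3 values shown sits, applies, so only a limit and no number is known. Among the measured compounds shown here, the single step that can be measured runs between compounds that share one aryl group on the shared core and differ only in the side group: an at least 4.7-fold higher number from compound 2 to compound 3 (0.67 log units; beyond the scatter), a change of substituent that is not the one considered here.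

Compound 4 `Nc1nc(-c2cccc(Cl)n2)nc2sc(Cc3ccccc3)cc12` differs from compound 1 at the other position: 6-chloropyridin-2-yl in place of 5-isopropylfuran-2-yl on an aromatic carbon. For the measured compounds named here, no measured pair reports a change of the aryl group at this place alone, since compound 1 and compound 2 differ in two places at once. Nothing in the data therefore points in a direction, and no step beyond the scatter is expected. Compound 4 is estimated at 250 nM, with a likely range from 80 nM to 800 nM, which amounts to an expected step of a 1.1-fold lower number from compound 1 to compound 4 (0.05 log units; within the scatter).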

Compound 4, inhibition constant: > 1000 nM
Compound 4 was reported as a limit; the forecaster's own chance of this, stated with the estimate: 15%; middle value at least 4.0-fold (0.60 log units) from the limit.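

In this assay, the aryl group on the carbon between two ring nitrogen atoms matters in its own right: with the rest of the molecule unchanged, 6-chloropyridin-2-yl in place of 5-isopropylfuran-2-yl gives an at least 3.5-fold higher number from compound 1 to compound 4 (0.54 log units; beyond the scatter). Among the compounds shown here, the earlier compounds offered a measured step only at the side group, from compound 2 to compound 3, so this is the first evidence that a change at this position alone can weaken inhibition beyond the scatter, even though both groups are single aromatic rings with one hetero atom and one hydrogen-bond acceptor. On these data alone, compound 4 is known only as a limit, so the step gives a minimum and its full size remains unknown: the limit of > 1000 nM in this assay, at which 1 of the 4 values shown sits.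

This one swap alters the ring size, the hetero atom and the substituent together, so the compounds shown cannot tell which of these changes matters, and they offer no cause for the weaker inhibition. An unsubstituted furan-2-yl or a 6-aminopyridin-2-yl group at this position would help separate the ring from its substituent, and so show whether the furan ring, the isopropyl group or the chlorine counts most.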